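A few compounds are considered here, and "the series" means these few. Any claim that something is new, unique, unknown or untested is made for them only; others in the source may bear on it.

Measured compounds:
compound 1, `NC(=O)c1ncn2c(=O)n(Cc3ccccc3)nnc12`, > 50000 nM
compound 2, `NC(=O)c1ncn2c(=O)n(Cc3ccco3)nnc12`, > 50000 nM
compound 3, `NC(=O)c1nc[nH]c1N/N=N/Cc1ccccc1`, > 50000 nM

In a functional assay on SNB-19 cells (Homo sapiens) for inhibition, read by MTT assay, with a stated time of 7 days (on this read-out lower numbers stand for stronger inhibition of growth and higher numbers for weaker inhibition of growth), compound 1 gives > 50000 nM, which is a limit of the assay and not a number. In this assay compound 2 gives > 50000 nM, again a limit. In this assay compound 3 gives > 50000 nM, also a limit. The change from compound 1 to compound 2 is furan-2-yl in place of phenyl on a saturated chain carbon bound to an aromatic nitrogen, and the step that the two limits leave unreadable from compound 1 to compound 2 cannot be sized. The difference between the core of compound 3 and the core of compound 1 is not broken down here.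

Compound 4, `NC(=O)c1nc[nH]c1N/N=N/Cc1ccco1`, is not yet measured. It differs from compound 3 by furan-2-yl in place of phenyl on a saturated chain carbon bound to a double-bonded nitrogen, the same kind of change as from compound 1 to compound 2, though the place differs: there the carbon was bound to an aromatic nitrogen, here to a double-bonded nitrogen. Because (the limit of > 50000 nM in this assay, at which 3 of the 3 values shown sit), the earlier step gives no readable size, so the step from compound 3 to compound 4 is estimated as a step that the limit leaves unreadable from compound 3 to compound 4. Compound 4 is expected to give 70000 nM, most likely again only a limit. For compound 4 the estimate spans 30000 nM to 300000 nM.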

Compound 4, concentration for 50% growth inhibition: > 50000 nM
Compound 4 ended at the assay's limit; the forecaster's own chance of this, stated with the estimate: 85%; the middle value does not contradict the limit.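

The step from compound 3 to compound 4 cannot be sized, because both compounds stand at a limit and not at a number: the limit of > 50000 nM in this assay, at which 4 of the 4 values shown sit. The compounds shown leave open how furan-2-yl and phenyl compare in this assay, on the core of compound 1 as well as on the core of compound 3.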